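The source may report more compounds than this note shows. Statements on the series, on what has been measured and on what is new or still open speak of the compounds shown alone.

In an ADME assay (liver) for metabolic stability, with Liver microsome (Homo sapiens) as the target, read by LC-MS, using microsomes, with a stated time of 15 min, tested at 5 uM (a higher number here means that more of the compound is left, a lower number that less of the compound is left), compound 1 `CC(=O)Nc1nc(C)c(-c2nc(CC(F)(F)F)no2)s1` gives 79.1% and compound 2 `CC(=O)Nc1nc(C)c(-c2nc(CC(C)(C)CO)no2)s1` gives 102%, the higher of the two numbers. Compound 3 `CC(=O)Nc1nc(C)c(-c2nc(CC(C)(C)C(C)O)no2)s1` differs from compound 2 by one change: methyl in place of hydrogen on a saturated chain carbon bound to an oxygen on a saturated carbon and a saturated chain carbon. Going by the values given here, the only measured step, a number 22.9 percentage points higher from compound 1 to compound 2 (beyond the scatter), replaces a different group and so bears only loosely on this change. A shift within the scatter, downward if anything, is therefore expected in this assay, an estimated a number 9 percentage points lower from compound 2 to compound 3 (within the scatter). For compound 3 the estimated value is 93%, with an expected range of 75% to 106%.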

Compound 3, percent of the compound remaining: 94.1%
The estimate for compound 3 lay 1.1 percentage points below the measured number; the measured number falls inside the stated range.
By their numbers in this assay, from the lowest: compound 1; then compounds 3 and 2 (each within the scatter of the next).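

With methyl in place of hydrogen on a saturated chain carbon bound to an oxygen on a saturated carbon and a saturated chain carbon, this assay shows a number 7.9 percentage points lower from compound 2 to compound 3 (within the scatter) and so no readable change at this position. The 2-hydroxy-1,1-dimethylpropyl group, in place of trifluoromethyl, still gives a number 15 percentage points higher from compound 1 to compound 3 (beyond the scatter) in this comparison. No supporting measurement bears on why either step takes this size. The compounds shown leave open whether an amine, a carboxylic acid or a longer chain at this carbon would hold up equally in this assay as well.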